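Bromo to benzyloxy: expected cytotoxicity of compound 3

The source may report more compounds than this note shows. Statements on the series, on what has been measured and on what is new or still open speak of the compounds shown alone.

Compound 1 `S=C(Nc1ccccc1)N1N=C(c2ccc(Br)cc2)CC1c1ccc2c(c1)OCCO2`: 152000 nM
Compound 2 `COc1cccc(C2=NN(C(=S)Nc3ccccc3)C(c3ccc4c(c3)OCCO4)C2)c1`: > 200000 nM, a limit of the assay, not a number

In an ADME assay on HEK-293T cells (Homo sapiens) for cytotoxicity, read by MTT assay, with a stated time of 48 h (on this read-out higher numbers stand for weaker inhibition of growth and lower numbers for stronger inhibition of growth), compound 1 gives 152000 nM, the only plain number shown here. For compound 2 the assay returns only the limit (the limit of > 200000 nM in this assay, at which 1 of the 2 values shown sits). Within the data shown here, the one measured step is an at least 1.3-fold higher number from compound 1 to compound 2 (0.11 log units; that floor lies within the scatter), which is a floor within the scatter and concerns the carbon with a double bond to nitrogen.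

Compound 3 `S=C(Nc1ccccc1)N1N=C(c2ccc(OCc3ccccc3)cc2)CC1c1ccc2c(c1)OCCO2` changes compound 1 elsewhere: benzyloxy in place of bromo on an aromatic carbon. Among the measured compounds shown here, no measured step touches this aromatic carbon, so the measured step gives no direction. Compound 3 is therefore expected to sit near compound 1, with the step of a 1.0-fold lower number from compound 1 to compound 3 (0.01 log units; within the scatter) expected to stay within the scatter. The estimate for compound 3 in this assay is 150000 nM, within a range from 50000 nM to 300000 nM.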

Compound 3, concentration for 50% growth inhibition: 175000 nM
Compound 3: the middle estimate sits 1.2-fold (0.07 log units) below what was measured, and the stated range covers the measured number.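

On this aromatic carbon, para to a large group, the change from bromo to benzyloxy adds a six-membered aromatic ring of carbon only, yet in this assay the result is a 1.2-fold higher number from compound 1 to compound 3 (0.06 log units; within the scatter). Among these compounds, this is the first readable step at this position, and it shows that a single halogen atom and a much larger group with its own ring cannot be told apart on this read-out. The earlier step could not show this, as it concerns another place and compound 2 gives a limit of the assay rather than a number: the limit of > 200000 nM in this assay, at which 1 of the 3 values shown sits.

On these data alone, it remains open whether an amine or a carboxylic acid on this aromatic carbon would also stay within the scatter of compound 1. As far as these compounds go, it is equally open whether a longer chain between the oxygen and the added ring would do so.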